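Pyrimidinyl Replaces Oxolanyl on the Triazole Nitrogen

The compounds below may be only part of what the source reports. "The series", "measured", "known", "first", "only" and "open" are said of these compounds alone.

Compound 1 `CN1C(=S)[C@@H](NC(=O)c2nc(Cc3ccccc3)n(CCCF)n2)COc2ccccc21`: in a toxicity assay on HT-29 cells (Homo sapiens) for cytotoxicity (on this read-out higher numbers stand for lower toxicity in this test and lower numbers for higher toxicity in this test), compound 1 gives > 100000 nM, a limit of the test rather than a number.
Compound 2 `CN1C(=S)[C@@H](NC(=O)c2nc(Cc3ccccc3)n(CCCCCC#N)n2)COc2ccccc21`: compound 2 gives > 100000 nM, again a limit.
Compound 3 `CN1C(=S)[C@@H](NC(=O)c2nc(Cc3ccccc3)n(C3CCOC3)n2)COc2ccccc21`: compound 3 gives > 100000 nM, also a limit.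

Compound 3 therefore does not stand at a measured point; it sits, with the two others, at the limit of > 100000 nM in this assay, at which 3 of the 3 values shown sit. None of the three compounds showed toxicity toward these cells within the concentrations tested.

The next change leads from compound 3 to compound 4 `CN1C(=S)[C@@H](NC(=O)c2nc(Cc3ccccc3)n(-c3ncccn3)n2)COc2ccccc21`. The difference is pyrimidin-2-yl in place of oxolan-3-yl on an aromatic nitrogen.

For the measured compounds named here, three measured steps bear on this change, all of them exchanges at the same aromatic nitrogen or on the chain attached to it: a step that the two limits leave unreadable from compound 1 to compound 2, a step that the two limits leave unreadable from compound 1 to compound 3 and a step that the two limits leave unreadable from compound 2 to compound 3. Because every compound sits at the limit of > 100000 nM in this assay, at which 3 of the 3 values shown sit, none of these steps can be read as a number in either direction. Going by the values given here, they show only that quite different groups at this position all left the compounds without measurable toxicity.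

On this basis compound 4 is expected to behave the same way, and its step from compound 3 is estimated as a step that the limit leaves unreadable from compound 3 to compound 4. Compound 4 is estimated at 150000 nM, with a range from 40000 nM to 600000 nM, most likely reported again as a limit.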

Compound 4, half-maximal cytotoxic concentration: > 100000 nM
Compound 4 ended at the assay's limit (the forecaster's own chance of this, stated with the estimate: 85%); the middle value lies beyond the limit too.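

The steps to compound 4 from compound 1, compound 2 and compound 3 cannot be read, since all four compounds rest at a limit of the test rather than at a number: the limit of > 100000 nM in this assay, at which 4 of the 4 values shown sit.

The compounds shown leave open how far each lies beyond that limit, and whether any group on this aromatic nitrogen would bring measurable toxicity in this assay.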